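The source may hold more compounds than are shown below. What is called first, only, known or untested is meant among the compounds shown, and "the series" means these compounds.

Compound 2 `CC(C(=O)NCc1ccc(C(F)(F)F)nc1N1CCC(Cc2ccc(F)c(F)c2)CC1)c1ccc(NS(C)(=O)=O)c(F)c1` is the stronger inhibitor of the two measured compounds: in a functional assay on CHO-K1 cells for antagonist activity at transient receptor potential cation channel subfamily V member 1 (Homo sapiens), read by FLIPR (on this read-out higher numbers stand for weaker inhibition and lower numbers for stronger inhibition), compound 2 gives 30 nM, whereas compound 1 `Cc1ccc(Cl)cc1Nc1nc(C(F)(F)F)ccc1CNC(=O)C(C)c1ccc(NS(C)(=O)=O)c(F)c1` gives 140 nM in this assay, a gap beyond the usual scatter. Compound 3 `CCCCOC1CCN(c2nc(C(F)(F)F)ccc2CNC(=O)C(C)c2ccc(NS(C)(=O)=O)c(F)c2)CC1` differs from compound 2 by a single change: butoxy in place of 3,4-difluorobenzyl on a saturated ring carbon. For the measured compounds named here, since no measured pair shows this exchange, the step from compound 2 to compound 3 is expected to be a moderate loss, a 3.0-fold higher number from compound 2 to compound 3 (0.48 log units; beyond the scatter). Compound 3 is therefore estimated at 90 nM in this assay, within a range from 25 nM to 400 nM.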

Compound 3, half-maximal inhibitory concentration: 28.2 nM
Beside the measured number, compound 3's estimate is 3.2-fold (0.50 log units) above it; the measured number falls inside the stated range.
By their numbers in this assay, from the lowest: compounds 3 and 2 (each within the scatter of the next); then compound 1.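

Exchanging the 3,4-difluorobenzyl for butoxy on this saturated ring carbon gives a 1.1-fold lower number from compound 2 to compound 3 (0.03 log units; within the scatter) in this assay, so here a chain with no ring and one oxygen serves as well as the aromatic group. The step of a 5.0-fold lower number from compound 1 to compound 3 (0.70 log units; beyond the scatter) shows that butoxy on the six-membered non-aromatic ring also keeps the advantage over the group of compound 1. Nothing shown explains why butoxy and 3,4-difluorobenzyl read alike. On these data alone, whether a shorter ether such as methoxy, an amine or a carboxylic acid on the same ring carbon would hold this level stays open.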